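Trimming a methyl from the cyclopropyl ring

This account rests on a few compounds, and the source may have more. Where it says the series, first, only, none or still open, it means among the compounds named here.

In an assay on HEK293 cells for activation of Kir3.1/Kir3.2 (Homo sapiens), read by thallium flux (a lower number here means a smaller maximal response, a higher number a larger maximal response), compound 1, `Cc1cc(NC(=O)Cn2nnc(-c3ccccc3)n2)n(C(C)C)n1`, gives 107%. Compound 2, `Cc1cc(NC(=O)Cn2nnc(-c3ccccc3)n2)n(C2CC2)n1`, carries a cyclopropyl in place of the isopropyl on the aromatic nitrogen. For compound 2 this assay reports > 78%, which is a limit of the assay rather than a number: the limit of > 78% in this assay, at which 1 of the 3 values shown sits. Among the measured compounds shown here, the only measured step between compounds that differ in one place, a step that the limit leaves unreadable from compound 1 to compound 2, therefore has no readable size.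

Compound 3, `CC1CC1c1cc(NC(=O)Cn2nnc(-c3ccccc3)n2)n(C2CCCCC2)n1`, gives 78% in this assay. Of the two plain numbers it stands lowest, and compound 1 stands higher by more than the usual scatter. Compound 4, `O=C(Cn1nnc(-c2ccccc2)n1)Nc1cc(C2CC2)nn1C1CCCCC1`, differs from compound 3 by hydrogen in place of methyl on a saturated ring carbon. For the measured compounds named here, no measured step touches this saturated ring carbon, and the single recorded step cannot be sized, so nothing in the data points to a shift beyond the scatter. Compound 4 is therefore expected to give 78%, with a range from 55% to 100%. The expected step is no change at the digits printed from compound 3 to compound 4 (within the scatter), which means no movement beyond the usual scatter.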

Compound 4, largest response reached (Emax), in percent of the reference or control that the assay uses: 45%
The estimate for compound 4 lay 33 percentage points above the measured number, and the stated range ends above it.
By their numbers in this assay, from the lowest: compound 4; then compound 3; then compound 1.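

In this assay, among the compounds shown here, the change from 2-methylcyclopropyl to cyclopropyl gives a number 33 percentage points lower from compound 3 to compound 4 (beyond the scatter), and it is the first step whose size can be read. It shows that this saturated ring carbon is sensitive: one methyl, a single carbon with no hydrogen-bond donor or acceptor and no charge, separates two clearly different maximal responses. Nothing in the data shown explains why this one methyl carries so much weight.

As far as these compounds go, whether an ethyl, a methoxy group or an amine on the same ring carbon would keep the response of compound 3, raise it or lower it remains open. Also open, from the compounds shown here alone, is whether swapping methyl for hydrogen here would have the same effect with isopropyl on the aromatic nitrogen.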